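The compounds below may be only part of what the source reports. "The series", "measured", "known", "first", "only" and "open" are said of these compounds alone.

Working notes on the shared core of compound 1 `CCc1cccc(NC(=O)c2cccc(/C=C3\CC(=O)N(c4ccccc4)C3=O)c2)c1`. In an ADME assay on SW480 cells (Homo sapiens) for cytotoxicity, read by MTT assay, with a stated time of 72 h (a higher number here means a weaker inhibitor, a lower number a stronger inhibitor), compound 1 gives 88600 nM. Compound 2 `Cc1cccc(NC(=O)c2cccc(/C=C3\CC(=O)N(c4ccccc4)C3=O)c2)c1` reaches only a limit of the assay, > 100000 nM. Compound 3 `O=C(Nc1ccc(OC(F)F)cc1)c1cccc(/C=C2\CC(=O)N(c3ccccc3)C2=O)c1` likewise stops at a limit, > 100000 nM; it therefore stands among the weak numbers shown, together with the limit of > 100000 nM in this assay, at which 2 of the 3 values shown sit. Compound 4 `O=C(NCc1ccccc1)c1cccc(/C=C2\CC(=O)N(c3ccccc3)C2=O)c1` differs from compound 3 by benzyl in place of 4-(difluoromethoxy)phenyl on an amide-type nitrogen. The measured steps at the same amide-type nitrogen are an at least 1.1-fold higher number from compound 1 to compound 3 (0.05 log units; that floor lies within the scatter) and a step that the two limits leave unreadable from compound 2 to compound 3, and the side-chain change gives an at least 1.1-fold higher number from compound 1 to compound 2 (0.05 log units; that floor lies within the scatter); none of them reads as a change beyond the scatter. Compound 4 is expected to remain at that limit, so the step of a number no higher from compound 3 to compound 4 (the limit leaves the size open) is estimated as none beyond the scatter. Compound 4 is estimated at 100000 nM, within 50000 nM to 300000 nM.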

Compound 4, half-maximal inhibitory concentration: > 100000 nM
Compound 4: no number, only a limit; the forecaster's own chance of this, stated with the estimate: 60%; the middle value lies on the limit itself.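

Benzyl on the amide-type nitrogen, the first group here that is not a directly attached substituted phenyl, gives the same assay outcome as the 3-methylphenyl and 4-(difluoromethoxy)phenyl groups in this assay: the limit of > 100000 nM in this assay, at which 3 of the 4 values shown sit.

Set against the 3-ethylphenyl group, benzyl gives an at least 1.1-fold higher number from compound 1 to compound 4 (0.05 log units; that floor lies within the scatter). The steps to compound 4 from compound 2 and compound 3 cannot be read.

On these data alone, it remains open whether any group on this nitrogen gives a number clearly beyond the scatter of these results. A longer chain in place of benzyl, or an amine or a carboxylic acid on its ring, would test this.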